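A few compounds are considered here, and "the series" means these few. Any claim that something is new, unique, unknown or untested is made for them only; others in the source may bear on it.

Measured in a functional assay on KB cells (Homo sapiens) for antiproliferative activity, read by sulforhodamine B assay, with a stated time of 3 days; a lower number here means that less compound is needed, a higher number that more compound is needed for the effect:
compound 1 `CCC1=C(O)c2c(oc(-c3ccc(C(F)(F)F)cc3)cc2=O)C(CC)(CC)C1=O`: 35.7 uM
compound 2 `CCOc1ccc(-c2cc(=O)c3c(o2)C(CC)(CC)C(=O)C(CC)=C3O)cc1`: > 52.4 uM

Compound 2 gives no number, only a limit of the assay: it stands at the limit of > 52.4 uM in this assay, at which 1 of the 2 values shown sits. Compound 3 `CCC1=C(O)c2c(oc(-c3ccc(Br)cc3)cc2=O)C(CC)(CC)C1=O` keeps the shared core and carries bromo in place of ethoxy on an aromatic carbon, 4-ethoxyphenyl becoming 4-bromophenyl: bromo in place of ethoxy on an aromatic carbon.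

Among the compounds with values here, one measured step bears on this change, an at least 1.4-fold higher number from compound 1 to compound 2 (0.16 log units; that floor lies within the scatter). Within the data shown here, it concerns the same place and also involves the ethoxy group, but no step to bromo has been measured. Compound 1, without ethoxy, gives 35.7 uM, so a modest move to a lower number is expected for compound 3, though it may not clear the scatter. The expected change is an at least 1.7-fold lower number from compound 2 to compound 3 (0.24 log units; that floor lies within the scatter). Compound 3 is estimated at 30 uM, with an expected range from 12 uM to 60 uM.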

Compound 3, concentration for half-maximal effect: > 48.1 uM
Compound 3 ended at the assay's limit; the forecaster's own chance of this, stated with the estimate: 30%; middle value at least 1.6-fold (0.20 log units) away from the limit.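

In this assay compound 3 gives > 48.1 uM, which is a limit of the assay and not a number. Bromo on this aromatic carbon, para to a large group, thus joins ethoxy in giving no number, leaving only the trifluoromethyl compound with a measured value. Bromo in place of trifluoromethyl gives an at least 1.3-fold higher number from compound 1 to compound 3 (0.12 log units; that floor lies within the scatter), so this change cannot be told apart from no change, and the step from ethoxy to bromo cannot be read, as both of its ends are limits.

From the compounds shown here alone, how far compound 2 and compound 3 lie beyond their limits remains open, so the three groups cannot be ranked. Also open, going by these compounds, is whether an amine or a carboxylic acid on this aromatic carbon would give a clearly lower number than the trifluoromethyl compound.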